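Extending the Methoxy of Compound 2 to Phenethyloxy

The source may hold more compounds than are shown below. What is called first, only, known or untested is meant among the compounds shown, and "the series" means these compounds.

Measured compounds:
compound 1, `CCCn1ccc2cc(-c3ccc(N(C)C)nc3)cc(Cl)c2c1=O`: 85%
compound 2, `CCCn1ccc2cc(-c3ccc(OC)nc3)cc(Cl)c2c1=O`: 121%
compound 3, `CCCn1ccc2cc(-c3cnc(OC)c(F)c3)cc(Cl)c2c1=O`: 75%

All three compounds share one core and differ only in the groups on the attached pyridine ring. In a functional assay on CHO cells for agonist activity at metabotropic glutamate receptor 2 (Homo sapiens), read by GTPgammaS binding (a higher number here means a larger maximal response, a lower number a smaller maximal response), compound 2 gives 121%, the highest of the three numbers; the nearest is compound 1, and the furthest is compound 3, with both gaps beyond the scatter. The two measured steps were both large: a number 36 percentage points higher from compound 1 to compound 2 (beyond the scatter), and a number 46 percentage points lower from compound 2 to compound 3 (beyond the scatter).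

Compound 4, `CCCn1ccc2cc(-c3ccc(OCCc4ccccc4)nc3)cc(Cl)c2c1=O`, differs from compound 2 by benzyl in place of hydrogen on a saturated chain carbon bound to an oxygen on an aromatic ring. Neither measured step is of this kind: one exchanges the group on the pyridine ring itself, the other adds a fluoro to that ring, whereas here the methoxy is lengthened to phenethyloxy while the ring keeps its substitution. Within the data shown here, there is therefore no measured step that tells how this lengthening moves the maximal response, only a hint that changes around this ring have moved it strongly in both directions.

With that uncertainty, compound 4 is expected to give 95% in this assay, within a range from 55% to 130%. This estimate means a step of a number 26 percentage points lower from compound 2 to compound 4 (beyond the scatter), which is expected to be a modest decrease and may lie within the scatter.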

Compound 4, largest response reached (Emax), in percent of the reference or control that the assay uses: 103%
For compound 4 the middle estimate is 8 percentage points below the measured one, and the stated range covers the measured number.
By their numbers in this assay, from the lowest: compounds 3 and 1 (each within the scatter of the next); then compound 4; then compound 2.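

In this assay, lengthening methoxy to phenethyloxy gives a number 18 percentage points lower from compound 2 to compound 4 (beyond the scatter), so a benzyl on the saturated chain carbon bound to the oxygen lowers the maximal response only modestly, and compound 4 keeps much of the response of compound 2. Exchanging dimethylamino for phenethyloxy on the same aromatic carbon gives a number 18 percentage points higher from compound 1 to compound 4 (beyond the scatter), which shows that this much larger group can still outperform a far smaller one at this place, so the response here does not simply fall as the group grows. Among these compounds, nothing measured so far accounts for either shift, and the size of a group alone cannot be offered as the explanation.

A single lengthening cannot show how the response follows the length of the chain, so groups such as ethoxy or benzyloxy could fall anywhere relative to methoxy and phenethyloxy. Also open, from the compounds shown here alone, is what a fluoro or a methoxy on the aromatic ring of the phenethyl, or an amine at the end of the chain, would do, and whether the fluoro of compound 3 would have a similar effect when combined with phenethyloxy.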